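This account rests on a few compounds, and the source may have more. Where it says the series, first, only, none or still open, it means among the compounds named here.

In an assay on CHO cells for displacement of a labelled ligand from adenosine receptor A3 (Homo sapiens), read by scintillation counting, tested at 10 uM (a lower number here means less inhibition, a higher number more inhibition at the concentration tested (going by the name of the read-out)), compound 1 `Cc1csc(N)c1C(=O)c1ccc(Cl)cc1` gives 1%. Compound 2 `CC(C)(C)Cc1c(-c2ccc(F)cc2F)sc(N)c1C(=O)c1ccc(Cl)cc1` gives 1% in this assay, level with compound 1 at the digits shown, so neither compound displaces the labelled ligand to any noticeable degree. Compound 3 `CC(C)(C)Cc1c(Br)sc(N)c1C(=O)c1ccc(Cl)cc1` differs from compound 2 in a single place: bromo in place of 2,4-difluorophenyl on an aromatic carbon. A step within the scatter is expected in this assay because compound 2 gives only 1%, leaving little room for a decrease and no sign that a change at this position raises inhibition. Compound 3 is therefore estimated at 3%, with a range from -8% to 14%, which means an expected step of a number 2 percentage points higher from compound 2 to compound 3 (within the scatter).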

Compound 3, a percentage reported as inhibition, at one concentration (the size of the read-out at that concentration, not a potency): 1%
For compound 3 the middle estimate is 2 percentage points above the measured one, and the stated range covers the measured number.
By their numbers in this assay, from the lowest: compounds 1, 2 and 3 (each within the scatter of the next).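

Putting bromo in place of 2,4-difluorophenyl on the aromatic carbon next to the ring sulfur shows no change at the digits printed from compound 2 to compound 3 (within the scatter) in this assay and so removes a whole six-membered aromatic ring without moving the read-out. With all readings this low, the step cannot show whether either group would matter in a compound that does displace the labelled ligand. Nothing available explains this flat result.
Going by these compounds, whether an amine or a carboxylic acid on this aromatic carbon would give a higher reading stays open.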